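From Compound 2 to a Longer Acid Chain

A few compounds are considered here, and "the series" means these few. Any claim that something is new, unique, unknown or untested is made for them only; others in the source may bear on it.

In an ADME assay on cells (spleen, Mus musculus, strain C57BL/6) for inhibition, read by flow cytometry and propidium iodide staining, with a stated time of 24 h, at 37 degrees C (on this read-out lower numbers stand for an effect already at smaller amounts and higher numbers for an effect only at larger amounts of compound), compound 1 (`O=C(Cn1cc(C(=O)O)nn1)NCc1ccccc1`) is reported as "non-toxic" (no number reported), with no number given. Among the measured compounds shown here, compound 2 (`O=C(O)CCc1cn(CC(=O)NCc2ccccc2)nn1`) gives 1420 uM, the only number available so far. Compound 3 (`O=C(O)CCCCc1cn(CC(=O)NCc2ccccc2)nn1`) differs from compound 2 by 2-carboxyethyl in place of carboxy on a saturated chain carbon, two bonds along the chain from an aromatic carbon, a change on a saturated chain carbon, two bonds along the chain from an aromatic carbon. For the measured compounds named here, no measured step guides this change, so the step expected in this assay is small, towards lower numbers and within the scatter: a 1.6-fold lower number from compound 2 to compound 3 (0.20 log units; within the scatter). For compound 3 the estimated value is 900 uM, with an expected range of 350 uM to 2300 uM.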

Compound 3, concentration for half-maximal effect: 1080 uM
Estimate against measurement, compound 3: 1.2-fold (0.08 log units) below; the range from low to high includes it.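

In this assay, among the compounds shown here, the first readable step at this position is a 1.3-fold lower number from compound 2 to compound 3 (0.12 log units; within the scatter). Replacing carboxy with 2-carboxyethyl on a saturated chain carbon, two bonds along the chain from an aromatic carbon, therefore leaves compound 3 indistinguishable from compound 2 on this read-out, so the added chain length does not separate the two. Nothing available here explains this result. As far as these compounds go, it remains open whether an amine or a methyl ester in place of the carboxylic acid at the chain end would leave the number similarly unchanged.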